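Aryl amide change from compound 3 to compound 4

This account rests on a few compounds, and the source may have more. Where it says the series, first, only, none or still open, it means among the compounds named here.

In a functional assay on NCI-H23 cells (Homo sapiens) for antiproliferative activity, read by MTT assay, with a stated time of 72 h (a lower number here means a stronger inhibitor, a higher number a weaker inhibitor), compound 3 (`C=CC(=O)Nc1cc(Nc2nccc(NC(=O)c3cccc(OC)c3)n2)c(OC)cc1N(C)CCN(C)C`) gives 11800 nM and stands within the scatter of the two other measured compounds. These are compound 1 (`C=CC(=O)Nc1cc(Nc2nccc(NC(=O)c3cccc4ccccc34)n2)c(OC)cc1N1CCN(C)CC1`), which gives 10600 nM in the same test, and compound 2 (`C=CC(=O)Nc1cc(Nc2nccc(NC(=O)c3cccc(OC)c3)n2)c(OC)cc1N1CCN(C)CC1`), which gives 15900 nM there too.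

Compound 4 (`C=CC(=O)Nc1cc(Nc2nccc(NC(=O)c3ccc(C(F)(F)F)cc3)n2)c(OC)cc1N(C)CCN(C)C`) carries 4-(trifluoromethyl)phenyl in place of 3-methoxyphenyl on a carbonyl carbon. The most relevant measured change lies at this same carbonyl carbon: a 1.5-fold higher number from compound 1 to compound 2 (0.18 log units; within the scatter) with 3-methoxyphenyl in place of naphthalen-1-yl, a step within the scatter. The other measured change, a 1.3-fold lower number from compound 2 to compound 3 (0.13 log units; within the scatter) with (2-(dimethylamino)ethyl)(methyl)amino in place of 4-methylpiperazin-1-yl, lies on an aromatic carbon and is also within the scatter. It bears on the new change only as a sign of how little the numbers have moved so far.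

Within the data shown here, no measured compound carries trifluoromethyl, so the evidence for this exact change is thin, and three compounds fix no firm trend. The expected change is a 1.1-fold lower number from compound 3 to compound 4 (0.03 log units; within the scatter) in this assay and thus none beyond the scatter. For compound 4 the estimated value is 11000 nM (expected range 5000 nM to 24000 nM).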

Compound 4, half-maximal inhibitory concentration: 7980 nM
Compound 4: the middle estimate sits 1.4-fold (0.14 log units) above what was measured; low and high end bracket the measured number.
By their numbers in this assay, from the lowest: compounds 4, 1, 3 and 2 (each within the scatter of the next).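

In this assay, the exchange of 3-methoxyphenyl for 4-(trifluoromethyl)phenyl on this carbonyl carbon gives a 1.5-fold lower number from compound 3 to compound 4 (0.17 log units; within the scatter). The entering group has more heavy atoms than the leaving one and no hydrogen-bond acceptor where the leaving group has one, yet the step stays within the scatter, so neither difference shows up as a measurable shift in this assay. The earlier step at this carbon, a 1.5-fold higher number from compound 1 to compound 2 (0.18 log units; within the scatter), was read with 4-methylpiperazin-1-yl on the aromatic carbon, whereas this one is read with (2-(dimethylamino)ethyl)(methyl)amino there, so the flat result at the carbonyl carbon now holds with both groups, and no measurement on hand offers any explanation for the size of the step.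

Still open, from the compounds shown here alone, is whether any group on this carbonyl carbon moves the number beyond the scatter, for instance a phenyl ring carrying a carboxylic acid or a primary amine, or a saturated ring in place of the aromatic one. Also open, going by these compounds, is whether 4-(trifluoromethyl)phenyl behaves the same way with 4-methylpiperazin-1-yl on the aromatic carbon.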